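Three Near-Identical Cytotoxicity Readings and a Fourth Compound

The source may report more compounds than this note shows. Statements on the series, on what has been measured and on what is new or still open speak of the compounds shown alone.

The compounds measured so far in a functional assay on PC-12 cells (Rattus norvegicus) for cytotoxicity, read by MTT assay, with stated times of 2 h and 24 h, tested at 5 uM (a lower number here means a weaker effect, a higher number a stronger effect of the compound at the concentration tested), are:
Compound 1 `COc1ccc(-n2nc(-c3ccc(C(F)(F)F)cc3O)nc2-c2ccccc2O)cc1`: 86.6%
Compound 2 `Oc1cc(C(F)(F)F)ccc1-c1nc(-c2ccccc2O)n(-c2ccc(OC(F)(F)F)cc2)n1`: 84.9%
Compound 3 `N#Cc1ccc(-n2nc(-c3ccc(C(F)(F)F)cc3O)nc2-c2ccccc2O)cc1`: 86.8%

Compound 3 holds the highest of the three numbers, yet the steps of a number 0.2 percentage points higher from compound 1 to compound 3 (within the scatter) and a number 1.9 percentage points higher from compound 2 to compound 3 (within the scatter) both stay inside the scatter, so the three compounds cannot be told apart. Compound 4 `Oc1cc(C(F)(F)F)ccc1-c1nc(-c2ccccc2O)n(-c2cccc(Cl)c2)n1` differs from compound 3 in one place: 3-chlorophenyl in place of 4-cyanophenyl on an aromatic nitrogen. All three measured steps, a number 1.7 percentage points lower from compound 1 to compound 2 (within the scatter), a number 0.2 percentage points higher from compound 1 to compound 3 (within the scatter) and a number 1.9 percentage points higher from compound 2 to compound 3 (within the scatter), also altered the group carried by the phenyl on that aromatic nitrogen and none moved the reading beyond the scatter. For compound 4 the step of a number 0.8 percentage points lower from compound 3 to compound 4 (within the scatter) is therefore expected to be small. Compound 4 is estimated at 86%, between 78% and 93%.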

Compound 4, a percentage reported as activity, at one concentration (the size of the read-out at that concentration, not a potency): 92.7%
Estimate against measurement, compound 4: 6.7 percentage points below; the measured number falls inside the stated range.
By their numbers in this assay, from the lowest: compounds 2, 1, 3 and 4 (each within the scatter of the next).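

Placing 3-chlorophenyl on the aromatic nitrogen gives a number 5.9 percentage points higher from compound 3 to compound 4 (within the scatter), a number 6.1 percentage points higher from compound 1 to compound 4 (within the scatter) and a number 7.8 percentage points higher from compound 2 to compound 4 (within the scatter) in this assay. These steps are larger than those among the three earlier compounds, yet even a group with its substituent at a different place on the phenyl stays within the scatter, so this position has shown no readable difference across all four groups. No measured evidence here bears on this result. Going by these compounds, whether an amine or a carboxylic acid on that phenyl would move the reading beyond the scatter remains open.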